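Chloro to cyano at the assay limit

The compounds below may be only part of what the source reports. "The series", "measured", "known", "first", "only" and "open" are said of these compounds alone.

Compound 1 `O=c1[nH]c2ccc(-c3csc(-c4ccccc4)n3)cc2o1`: > 50000 nM
Compound 2 `O=c1[nH]c2ccc(-c3csc(-c4ccc(Cl)cc4)n3)cc2o1`: > 50000 nM

Both entries are limits of the assay and not numbers. In a functional assay on TOV21G cells (Homo sapiens) for antiproliferative activity, read by sulforhodamine B assay, with a stated time of 5 days (a higher number here means a weaker inhibitor of growth, a lower number a stronger inhibitor of growth), compound 2 gives > 50000 nM, which is a limit. The evidence so far is the limit of > 50000 nM in this assay, at which 2 of the 2 values shown sit. Going by the values given here, the only measured step is a step that the two limits leave unreadable from compound 1 to compound 2, so it offers no size to carry forward.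

Compound 3 `N#Cc1ccc(-c2nc(-c3ccc4[nH]c(=O)oc4c3)cs2)cc1` differs from compound 2 by cyano in place of chloro on an aromatic carbon, para to a large group. With no readable step to draw on, no change beyond the scatter is expected in this assay, and weak growth inhibition should persist. Compound 3 is estimated at 50000 nM, with an expected range of 20000 nM to 100000 nM. This estimate means an expected step of a number no higher from compound 2 to compound 3 (the limit leaves the size open).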

Compound 3, concentration for 50% growth inhibition: > 50000 nM
Compound 3: only a limit was reported (the forecaster's own chance of this, stated with the estimate: 80%); the middle value lies on the limit itself.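

Going by these compounds alone, compound 3 gives only a limit in this assay, as compound 1 and compound 2 do, so neither the step to compound 3 from compound 2 nor the one from compound 1 can be read. The compounds shown leave open whether any group in this place can bring growth inhibition to a readable number.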